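Methoxy Substitution on a Phenyl Ring Across Two Cores

The source may report more compounds than this note shows. Statements on the series, on what has been measured and on what is new or still open speak of the compounds shown alone.

Compound 1 `CC(C)=CCC/C(C)=C/CC/C(C)=C/CC[C@@H]1[C@@]2(C)CC/C(=N\OCc3cn(-c4ccccc4)nn3)C(C)(C)[C@@H]2CC[C@@]1(C)O` and compound 2 `COc1cccc(-n2cc(CO/N=C3\CC[C@]4(C)[C@@H](CC/C=C(\C)CC/C=C(\C)CCC=C(C)C)[C@](C)(O)CC[C@H]4C3(C)C)nn2)c1` share one core; compound 2 carries methoxy in place of hydrogen on an aromatic carbon. In a functional assay on DU-145 cells (Homo sapiens) for cytotoxicity, read by MTT assay, with a stated time of 48 h (on this read-out lower numbers stand for stronger inhibition and higher numbers for weaker inhibition), compound 1 gives 8830 nM, and compound 2 gives 30500 nM, so the change made a 3.5-fold higher number from compound 1 to compound 2 (0.54 log units; beyond the scatter). Compound 3 `CC(C)=CCC/C(C)=C/CC/C(C)=C/CC[C@@H]1[C@@]2(C)C/C(=C\c3ccc(OCc4cn(-c5ccccc5)nn4)cc3)C(=O)C(C)(C)[C@@H]2CC[C@@]1(C)O` rests on a different core, and the difference between the two cores is not broken down here. In this assay compound 3 gives 21000 nM. Compound 4 `COc1cccc(-n2cc(COc3ccc(/C=C4\C[C@]5(C)[C@@H](CC/C=C(\C)CC/C=C(\C)CCC=C(C)C)[C@](C)(O)CC[C@H]5C(C)(C)C4=O)cc3)nn2)c1` differs from compound 3 by methoxy in place of hydrogen on an aromatic carbon, the same change as that between compound 1 and compound 2, at the same kind of place. The step of a 2.6-fold higher number from compound 3 to compound 4 (0.42 log units; beyond the scatter) is expected in this assay because the same change gave a 3.5-fold higher number from compound 1 to compound 2 (0.54 log units; beyond the scatter), with some allowance since the cores differ. Compound 4 is therefore estimated at 55000 nM, within a range from 25000 nM to 120000 nM.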

Compound 4, half-maximal inhibitory concentration: 14500 nM
Compound 4: the middle estimate sits 3.8-fold (0.58 log units) above what was measured, outside the stated range (below it).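

On the core of compound 3, the phenyl to 3-methoxyphenyl change gave a 1.4-fold lower number from compound 3 to compound 4 (0.16 log units; within the scatter) in this assay. The size of the step seen on the core of compound 1 therefore did not carry over to this second core, and the two steps stand apart: the same change on two cores in this assay, a 3.5-fold higher number (0.54 log units; beyond the scatter) from compound 1 to compound 2 and a 1.4-fold lower number (0.16 log units; within the scatter) from compound 3 to compound 4, 5.0-fold (0.70 log units) apart, beyond the scatter of two such steps

This comparison rests on a single pair for each core, and it does not show which feature of the cores accounts for the gap or how the change would behave on any further core. The compounds shown leave open whether another group in place of the methoxy, such as an amine or a carboxylic acid, would give steps that agree across the two cores.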